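A few compounds are considered here, and "the series" means these few. Any claim that something is new, unique, unknown or untested is made for them only; others in the source may bear on it.

Compound 1, `COc1cc(N2C(=O)CC2c2ccc(SC)cc2)cc(OC)c1OC`, belongs to a small set in which a four-membered lactam core carries a trimethoxyphenyl group on its nitrogen and a 4-(methylsulfanyl)phenyl group on a ring carbon. In a functional assay on HT-29 cells (Homo sapiens) for inhibition, read by sulforhodamine B assay, with a stated time of 72 h (a lower number here means a stronger inhibitor, a higher number a weaker inhibitor), compound 1 gives 108 nM. Among the compounds with values here, the only other compound measured so far, compound 2, `CCOc1ccc(C2C(C3CC3)C(=O)N2c2cc(OC)c(OC)c(OC)c2)cc1`, gives 63 nM in this assay, and the two numbers lie within the scatter of each other, so compound 1 is neither stronger nor weaker than compound 2 on these data.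

Compound 3, `COc1cc(N2C(=O)C(O)C2c2ccc(SC)cc2)cc(OC)c1OC`, differs from compound 1 by a single change: hydroxy in place of hydrogen on a saturated ring carbon. Within the data shown here, no measured pair shows this change, so its effect is not known from the data. Compound 3 is expected to show a modest step toward a lower number, a 2.4-fold lower number from compound 1 to compound 3 (0.38 log units; beyond the scatter), and its estimated value in this assay is 45 nM, within a range of 10 nM to 200 nM.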

Compound 3, half-maximal inhibitory concentration: 15 nM
Estimate against measurement, compound 3: 3.0-fold (0.48 log units) above, within the range that was stated.
By their numbers in this assay, from the lowest: compound 3; then compounds 2 and 1 (each within the scatter of the next).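

In this assay, hydroxy in place of hydrogen on a saturated ring carbon of the shared core gives a 7.2-fold lower number from compound 1 to compound 3 (0.86 log units; beyond the scatter) and lies beyond the scatter, so this position responds to a single small change. The earlier compounds shown here could not show this, as compound 1 and compound 2 differ in more than one place. Nothing measured here accounts for the step.

The compounds shown leave open whether the lower number is specific to hydroxy or would also follow from another group on this ring carbon, such as an amine, a fluorine atom or an acetate. They also leave open whether hydroxy would give a step of similar size if the 4-(methylsulfanyl)phenyl group were replaced by another group.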